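Restoring an aromatic ring where compound 3 carries a propyl chain

A few compounds are considered here, and "the series" means these few. Any claim that something is new, unique, unknown or untested is made for them only; others in the source may bear on it.

Of the compounds shown here, three sharing one core have been measured in an in vitro functional assay on cells for agonist activity at Bombesin receptor subtype-3 (Mus musculus), read by luminescence and calcium flux; a lower number here means that less compound is needed, a higher number that more compound is needed for the effect. Compound 1 `O=C(O)c1ccccc1-c1ccc(CCc2ncc(Cc3ccccc3F)[nH]2)cc1` gives 9.5 nM, compound 2 `O=C(O)c1ccccc1-c1ccc(CCc2ncc(Cc3cccc(Cl)c3)[nH]2)cc1` gives 31 nM, and compound 3 `CCCCc1cnc(CCc2ccc(-c3ccccc3C(=O)O)cc2)[nH]1` gives 93 nM, the highest of the three numbers; a 3.0-fold higher number from compound 2 to compound 3 (0.48 log units; beyond the scatter) and a 9.8-fold higher number from compound 1 to compound 3 (0.99 log units; beyond the scatter) both lie beyond the scatter.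

Compound 4 `COc1ccccc1Cc1cnc(CCc2ccc(-c3ccccc3C(=O)O)cc2)[nH]1` differs from compound 3 in one place: 2-methoxyphenyl in place of propyl on a saturated chain carbon bound to an aromatic carbon. The two measured steps into compound 3 bear directly on this, since each replaced a six-membered aromatic ring with propyl and raised the number, by a 9.8-fold higher number from compound 1 to compound 3 (0.99 log units; beyond the scatter) and by a 3.0-fold higher number from compound 2 to compound 3 (0.48 log units; beyond the scatter). Reversing that kind of change, with a ring that again carries a single small group, is expected to lower the number in this assay, most likely to a value near compound 1 rather than compound 2.

Compound 4 is therefore expected to give about 15 nM, within a range of 5 nM to 50 nM, a step of a 6.2-fold lower number from compound 3 to compound 4 (0.79 log units; beyond the scatter).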

Compound 4, half-maximal effective concentration: 163 nM
Estimate against measurement, compound 4: 11-fold (1.04 log units) below; the measured number lies above the stated range.
By their numbers in this assay, from the lowest: compound 1; then compound 2; then compounds 3 and 4 (each within the scatter of the next).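

Putting an aromatic ring back at this position does not by itself lower the number: in this assay, replacing propyl with 2-methoxyphenyl gives a 1.8-fold higher number from compound 3 to compound 4 (0.24 log units; within the scatter), so these two compounds cannot be told apart. What the ring carries matters sharply, as methoxy in place of fluoro gives a 17-fold higher number from compound 1 to compound 4 (1.23 log units; beyond the scatter), and 2-methoxyphenyl in place of 3-chlorophenyl gives a 5.3-fold higher number from compound 2 to compound 4 (0.72 log units; beyond the scatter), making compound 4 the exception to the earlier picture of rings giving lower numbers than propyl. Nothing available here gives a reason for these differences.

As far as these compounds go, the step from compound 2 to compound 4 changes both the group and its place on the ring, so their separate contributions remain open. A 3-methoxyphenyl or 2-chlorophenyl group at this position would help separate them, and a 2-hydroxyphenyl group would test another small group there.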